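From 2-methylphenyl to 3-chloropyridin-4-yl in compound 3

The source may hold more compounds than are shown below. What is called first, only, known or untested is meant among the compounds shown, and "the series" means these compounds.

Compound 1 `CC/C(=C(/c1ccc(/C=C/C(=O)O)cc1)c1ccc2[nH]ncc2c1)c1ccccc1` gives 5800 ng.h/mL in an ADME assay on the whole organism for pharmacokinetics, with Mus musculus as the target, at a dose of 10 mg/kg by the oral route; on this read-out higher numbers stand for higher exposure at the dose given and lower numbers for lower exposure
Compound 2 `CC/C(=C(/c1ccc(/C=C/C(=O)O)cc1)c1ccc2[nH]ncc2c1)c1ccccc1Cl` gives 15000 ng.h/mL in this assay
Compound 3 `CC/C(=C(/c1ccc(/C=C/C(=O)O)cc1)c1ccc2[nH]ncc2c1)c1ccccc1C` gives 7200 ng.h/mL in this assay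

Compound 3 holds the middle place of these three numbers. Its value sits within the scatter of compound 1 and clearly under compound 2. Compound 4 `CC/C(=C(/c1ccc(/C=C/C(=O)O)cc1)c1ccc2[nH]ncc2c1)c1ccncc1Cl` has not been measured yet. It carries 3-chloropyridin-4-yl in place of 2-methylphenyl on a double-bonded chain carbon bound to a double-bonded chain carbon and a saturated chain carbon.

Among the measured compounds shown here, three measured steps bear on this change. Chloro in place of hydrogen gave a clear rise (a 2.6-fold higher number from compound 1 to compound 2 (0.41 log units; beyond the scatter)) and methyl in place of chloro gave a clear fall (a 2.1-fold lower number from compound 2 to compound 3 (0.32 log units; beyond the scatter)). Methyl in place of hydrogen changed little (a 1.2-fold higher number from compound 1 to compound 3 (0.09 log units; within the scatter)). These steps suggest that the chloro group of compound 4 could lift the number. For the measured compounds named here, no measured compound has a nitrogen in this ring, however, so the data give no step for that part of the change, and it could pull either way. The estimated change is therefore small and upward (a 1.3-fold higher number from compound 3 to compound 4 (0.10 log units; within the scatter)) and stays within the scatter. In this assay compound 4 is estimated at 9000 ng.h/mL with a range from 3500 ng.h/mL to 20000 ng.h/mL expected around it.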

Compound 4, area under the concentration-time curve: 110 ng.h/mL
Compound 4: the middle estimate sits 82-fold (1.91 log units) above what was measured; the whole stated range lies above it.
By their numbers in this assay, from the lowest: compound 4; then compounds 1 and 3 (each within the scatter of the next); then compound 2.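

In this assay, swapping among phenyl, 2-chlorophenyl and 2-methylphenyl on this double-bonded chain carbon gave only modest shifts at most, yet 3-chloropyridin-4-yl brings far larger falls against all three (a 53-fold lower number from compound 1 to compound 4 (1.72 log units; beyond the scatter)) (a 65-fold lower number from compound 3 to compound 4 (1.82 log units; beyond the scatter)) (a 140-fold lower number from compound 2 to compound 4 (2.13 log units; beyond the scatter)). The last of these steps is the most telling, since both rings carry a chloro group and differ only in that 3-chloropyridin-4-yl has a nitrogen in the ring, which adds a hydrogen-bond acceptor. So a chloro group that went with the highest number on a carbon-only ring gives no such result in this nitrogen-containing ring, and no measurement here explains the collapse.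

Going by these compounds, it remains open whether a pyridin-4-yl ring with methyl in place of chloro, or with no group there at all, would fall as steeply, and whether a nitrogen elsewhere in the ring would do the same. An exposure number alone also leaves open whether less compound enters the blood or the compound leaves it faster.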